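Adding a sulfonyl group to compound 3

The source may report more compounds than this note shows. Statements on the series, on what has been measured and on what is new or still open speak of the compounds shown alone.

Measured in an ADME assay on L02 cells (Homo sapiens) for cytotoxicity, read by MTT assay, with a stated time of 24 h; a higher number here means a weaker inhibitor, a lower number a stronger inhibitor:
Compound 1 `CN1C/C(=C\c2cccnc2)C(=O)/C(=C/c2ccccc2C(F)(F)F)C1`: 14100 nM
Compound 2 `Cc1ccc(S(=O)(=O)N2C/C(=C\c3cccnc3)C(=O)/C(=C/c3ccccc3F)C2)cc1`: 14900 nM
Compound 3 `O=C1/C(=C/c2cccnc2)CNC/C1=C\c1ccccc1C(F)(F)F`: 11300 nM

Compound 3 stands within the scatter of both other compounds, so the three numbers cannot be ranked. Compound 4 `Cc1ccc(S(=O)(=O)N2C/C(=C\c3cccnc3)C(=O)/C(=C/c3ccccc3C(F)(F)F)C2)cc1` has not yet been measured in this assay. It carries (4-methylphenyl)sulfonyl in place of hydrogen on an amine nitrogen in a ring of compound 3: (4-methylphenyl)sulfonyl in place of hydrogen on an amine nitrogen in a ring.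

For the measured compounds named here, only one measured step touches that nitrogen, a 1.2-fold lower number from compound 1 to compound 3 (0.10 log units; within the scatter). That step exchanges methyl for hydrogen, so it says little directly about the much larger group entering here. The closest evidence comes from compound 2, which already bears (4-methylphenyl)sulfonyl on the same nitrogen and gives 14900 nM. Going by the values given here, compound 2 also has fluorine where compound 4 has trifluoromethyl, so the comparison is indirect, and no measured step isolates either change. Even so, its number lies within the scatter of the number for compound 3, and no step beyond the scatter is expected. The expected change is a 1.2-fold higher number from compound 3 to compound 4 (0.08 log units; within the scatter). For compound 4 the estimated value is 13500 nM, with an expected range from 7500 nM to 24000 nM.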

Compound 4, half-maximal inhibitory concentration: 12300 nM
Beside the measured number, compound 4's estimate is 1.1-fold (0.04 log units) above it, within the range that was stated.
By their numbers in this assay, from the lowest: compounds 3, 4, 1 and 2 (each within the scatter of the next).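

In this assay, the step onto the amine nitrogen in a ring now has a direct reading for a large group: (4-methylphenyl)sulfonyl in place of hydrogen gives (a 1.1-fold higher number from compound 3 to compound 4 (0.04 log units; within the scatter)), and the same group in place of methyl gives (a 1.1-fold lower number from compound 1 to compound 4 (0.06 log units; within the scatter)), so hydrogen, methyl and (4-methylphenyl)sulfonyl on this nitrogen cannot be told apart here. For the compounds shown here, the result also supplies the first measured step at the aromatic carbon: with (4-methylphenyl)sulfonyl held on the nitrogen, trifluoromethyl in place of fluoro gives (a 1.2-fold lower number from compound 2 to compound 4 (0.08 log units; within the scatter)), which means that neither place has yet shifted the number beyond the scatter. No measurement is available to account for this flat reading at either place.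

The compounds shown leave open whether any group on this nitrogen can move the number beyond the scatter, for instance an acetyl group or a longer alkyl chain, or a carboxylic acid in place of the methyl of the (4-methylphenyl)sulfonyl group. Also open, as far as these compounds go, is whether trifluoromethyl and fluoro read alike when the nitrogen carries hydrogen or methyl instead.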